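Ring Exchange on Compound 3 Between Two Limits

The source may hold more compounds than are shown below. What is called first, only, known or untested is meant among the compounds shown, and "the series" means these compounds.

Compound 3 `Cc1ccccc1Nc1nc(C)c(C(=O)/C=C/c2ccc(Cl)cc2)s1` was tested in a functional assay on Bel-7402 cells (Homo sapiens) for cytotoxicity, read by MTT assay; a lower number here means a stronger inhibitor, a higher number a weaker inhibitor. In this assay compound 3 gives only a limit, > 25000 nM, not a number. Compound 1 `COc1cccc(/C=C/C(=O)c2sc(Nc3cccc(C)c3)nc2C)c1` likewise gives a limit in this assay, > 25000 nM. Compound 2 `COc1cccc(/C=C/C(=O)c2sc(Nc3ccccc3)nc2C)c1` also gives a limit in this assay, > 25000 nM. The only one-place step among these three, a step that the two limits leave unreadable from compound 1 to compound 2, is a hydrogen in place of methyl on an aromatic carbon, and its size cannot be read because the limit of > 25000 nM in this assay, at which 3 of the 3 values shown sit, shows every value sitting at that same limit.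

Compound 4 `COc1cccc(/C=C/C(=O)c2sc(Nc3ccccc3C)nc2C)c1` differs from compound 3 by 3-methoxyphenyl in place of 4-chlorophenyl on a double-bonded chain carbon bound to a double-bonded chain carbon. Among the measured compounds shown here, no measured step bears directly on this exchange; it moves compound 3 toward the ring that compounds 1 and 2 carry, while keeping the amine-side ring of compound 3. Compound 4 is therefore expected to give 30000 nM in this assay, somewhere between 10000 nM and 100000 nM, and most likely again only as a limit. The expected step, a step that the limit leaves unreadable from compound 3 to compound 4, is none beyond the scatter.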

Compound 4, half-maximal inhibitory concentration: > 25000 nM
Compound 4 was reported as a limit; the forecaster's own chance of this, stated with the estimate: 80%; the middle value lies beyond the limit too.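

No step from compound 1, compound 2 or compound 3 to compound 4 can be read, because each value is a limit and not a number: the limit of > 25000 nM in this assay, at which 4 of the 4 values shown sit.

The compounds shown leave open how strong any of them really is in this assay, and so whether these exchanges change anything.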